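A Ring Closure Tested on a Weak Pair

A few compounds are considered here, and "the series" means these few. Any claim that something is new, unique, unknown or untested is made for them only; others in the source may bear on it.

Measured so far in a functional assay on A549 cells (Homo sapiens) for inhibition; on this read-out lower numbers stand for stronger inhibition and higher numbers for weaker inhibition:
Compound 1 `CCN(C(=O)CC(CC(=O)NCCN1CCCC1)c1ccc(Cl)cc1)C1Cc2ccccc2C1` gives 22600 nM.
Compound 2 `CCNCCNC(=O)CC(CC(=O)N(CC)C1Cc2ccccc2C1)c1ccc(Cl)cc1` gives 19400 nM.
Compound 3 `CCNCCNC(=O)CC(CC(=O)N(CC)C1Cc2ccccc2C1)c1ccccc1` gives only a limit of the assay, > 100000 nM.

All three compounds share one core and differ in two places. From compound 2 to compound 1 the change is pyrrolidin-1-yl in place of ethylamino on a saturated chain carbon, two bonds along the chain from an amide-type nitrogen; the step of a 1.2-fold higher number from compound 2 to compound 1 (0.07 log units; within the scatter) leaves the two compounds indistinguishable. From compound 2 to compound 3 the change is hydrogen in place of chloro on an aromatic carbon; the step of an at least 5.1-fold higher number from compound 2 to compound 3 (0.71 log units; beyond the scatter) is a real loss. For compound 3 the reading stops at the boundary of what the assay can report, (the limit of > 100000 nM in this assay, at which 1 of the 3 values shown sits), so its value is a limit and not a number.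

Compound 4 `CCN(C(=O)CC(CC(=O)NCCN1CCCC1)c1ccccc1)C1Cc2ccccc2C1` has not yet been measured. It differs from compound 3 by pyrrolidin-1-yl in place of ethylamino on a saturated chain carbon, two bonds along the chain from an amide-type nitrogen. The place is the same word for word as in the change from compound 2 to compound 1, so this is the same change made on the core of compound 3. Because the step of a 1.2-fold higher number from compound 2 to compound 1 (0.07 log units; within the scatter) stayed within the scatter, compound 4 is expected to show a step that the limit leaves unreadable from compound 3 to compound 4 from compound 3. Compound 4 is therefore estimated at 150000 nM, between 60000 nM and 400000 nM, and the assay is most likely to report again only a limit rather than a number.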

Compound 4, half-maximal inhibitory concentration: > 100000 nM
Compound 4 gave a limit, no number; the forecaster's own chance of this, stated with the estimate: 85%; the middle value lies beyond the limit too.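

In this assay compound 4 gives > 100000 nM, a limit of the assay and not a number, and the step that puts pyrrolidin-1-yl in place of ethylamino on the core of compound 3 therefore cannot be read, with both partners now sitting at that boundary: the limit of > 100000 nM in this assay, at which 2 of the 4 values shown sit. On the chloro core the same change gave a 1.2-fold higher number from compound 2 to compound 1 (0.07 log units; within the scatter); the new result does not contradict this, but it does not confirm that the change is just as silent on the core without chloro, and so it cannot show that the change carries over from one core to the other. What can be read is the other change, hydrogen in place of chloro, which gives an at least 4.4-fold higher number from compound 1 to compound 4 (0.64 log units; beyond the scatter) and can be set beside the earlier loss: the same change on two cores in this assay, an at least 5.1-fold higher number (0.71 log units; beyond the scatter) from compound 2 to compound 3 and an at least 4.4-fold higher number (0.64 log units; beyond the scatter) from compound 1 to compound 4; the limit leaves it open whether they differ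

The compounds shown leave open whether a different group in place of chloro on that aromatic carbon, such as fluoro, bromo or methoxy, would keep a readable value. They also leave open how a piperidin-1-yl or a dimethylamino group in place of pyrrolidin-1-yl would compare, and how the amine change behaves on a core where both partners give numbers.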